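The source may report more compounds than this note shows. Statements on the series, on what has been measured and on what is new or still open speak of the compounds shown alone.

Three compounds have been measured in an assay on membranes from brain for binding affinity to adenosine receptor A1 (Rattus norvegicus), read by radioligand binding, tested at 20 uM; on this read-out higher numbers stand for more inhibition at the one concentration tested (going by the name of the read-out) and lower numbers for less inhibition:

Compound 1 `Cn1c(=O)[nH]c2c(cnn2-c2cccc(Cl)c2)c1=N`: 53%
Compound 2 `Cn1c(=O)[nH]c2c(cnn2-c2cc(Cl)cc(Cl)c2)c1=N`: 29%
Compound 3 `CCn1c(=O)[nH]c2c(cnn2-c2cccc(Cl)c2)c1=N`: 70%

Compound 1 stands second of the three. The nearest neighbour is compound 3, which lies higher by a number 17 percentage points higher from compound 1 to compound 3 (beyond the scatter); the furthest is compound 2, which lies lower by a number 24 percentage points lower from compound 1 to compound 2 (beyond the scatter). Both steps fall beyond the scatter of this assay.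

The step now followed leads from compound 1 to compound 4 `Cn1c(=O)[nH]c2c(cnn2-c2cccc(N)c2)c1=N`. The change is amino in place of chloro on an aromatic carbon.

Neither measured step is a close precedent. The step from compound 1 to compound 2 adds a second chloro to the same aromatic ring and lowers the read-out modestly; the step from compound 1 to compound 3 alters the saturated chain on the aromatic nitrogen and raises it modestly. For the measured compounds named here, nothing measured so far replaces the chloro itself. The one hint available is that the read-out on this ring is sensitive to what sits there, as the step from compound 1 to compound 2 shows. For compound 4 a modest decrease is therefore expected, a number 13 percentage points lower from compound 1 to compound 4 (beyond the scatter), with wide uncertainty. Compound 4 is estimated at 40%, within a range from 15% to 65%.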

Compound 4, a percentage reported as inhibition, at one concentration (the size of the read-out at that concentration, not a potency): 0%
Beside the measured number, compound 4's estimate is 40 percentage points above it; measured number below the stated range.
By their numbers in this assay, from the lowest: compound 4; then compound 2; then compound 1; then compound 3.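

In this assay, amino in place of chloro gives a number 53 percentage points lower from compound 1 to compound 4 (beyond the scatter), a large step that goes well past the modest one seen on this ring before, a number 24 percentage points lower from compound 1 to compound 2 (beyond the scatter). The earlier compounds shown here showed only that adding a second chloro to the ring lowers the number, whereas this step exchanges the single chloro itself, on an aromatic carbon meta to a large group, and compound 4 gives 0% at the one concentration tested, so in this pair the read-out depends heavily on which group occupies that carbon. Nothing available here explains why the exchange has so large an effect.

The compounds shown leave open whether a bromo, methyl or methoxy group on this carbon would keep the number near that of compound 1, or whether the chloro is unusual in doing so. They also leave open whether amino would bring so large a drop on the longer chain of compound 3, or whether that chain would recover part of the loss.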